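Aryl Swap on a Triazole Nitrogen: Expected Outcome for Compound 4

The compounds below may be only part of what the source reports. "The series", "measured", "known", "first", "only" and "open" are said of these compounds alone.

Compound 1 `N#CC1=C(N)Oc2c(c3nc4ccccc4nc3c3ccccc23)C12C(=O)N(Cc1cnnn1-c1ccc(Cl)cc1)c1ccccc12` gives > 50000 nM in an ADME assay on L02 cells (Homo sapiens) for antiproliferative activity, read by MTT assay, with a stated time of 48 h (a higher number here means a weaker inhibitor, a lower number a stronger inhibitor), a limit of the assay rather than a number.
Compound 2 `N#CC1=C(N)Oc2c(c3nc4ccccc4nc3c3ccccc23)C12C(=O)N(Cc1cnnn1-c1ccc(Cl)c(Cl)c1)c1ccccc12` gives > 50000 nM in this assay, again a limit rather than a number.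
Compound 3 `COc1ccc(-n2nncc2CN2C(=O)C3(C(C#N)=C(N)Oc4c(N)cc5nc6ccccc6nc5c43)c3ccccc32)cc1` gives > 50000 nM in this assay, also a limit rather than a number.

Compound 3 therefore stands at the same limit as the other two compounds, with every value shown sitting at that limit (the limit of > 50000 nM in this assay, at which 3 of the 3 values shown sit). Within the data shown here, the only step between measured compounds that differ in one place, a step that the two limits leave unreadable from compound 1 to compound 2, runs between two limits and so cannot be read for size or direction; it offers no guide beyond showing that both ends stayed at the limit.

Compound 4 `N#CC1=C(N)Oc2c(N)cc3nc4ccccc4nc3c2C12C(=O)N(Cc1cnnn1-c1ccc(F)c(Cl)c1)c1ccccc12` differs from compound 3 by 3-chloro-4-fluorophenyl in place of 4-methoxyphenyl on an aromatic nitrogen. Among the measured compounds shown here, no measured step bears readably on this change. Since compound 3 sits at the limit > 50000 nM, compound 4 is expected to remain near that limit, with a step of a number no higher from compound 3 to compound 4 (the limit leaves the size open) that is not expected to exceed the scatter. The estimate for compound 4 in this assay is 50000 nM, with a range from 20000 nM to 120000 nM, and most likely the assay will again report only a limit.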

Compound 4, half-maximal inhibitory concentration: > 50000 nM
Compound 4 ended at the assay's limit; the forecaster's own chance of this, stated with the estimate: 85%; the middle value lies on the limit itself.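

Compound 3 and compound 4 both end at a limit of the assay rather than a number, so no step can be read between them. The compounds shown leave open whether any of these aryl swaps changes the value at all, with every result at one limit: the limit of > 50000 nM in this assay, at which 4 of the 4 values shown sit.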